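The compounds below may be only part of what the source reports. "The series", "measured", "known", "first", "only" and "open" are said of these compounds alone.

Series so far, in a functional assay on MES-SA/Dx5 cells (Homo sapiens) for inhibition, with a stated time of 72 h; on this read-out higher numbers stand for weaker inhibition and lower numbers for stronger inhibition:

- compound 1 `Oc1c(C(c2cccnc2)N2CCCC2)ccc2cccnc12`: 23400 nM
- compound 2 `Oc1c(C(c2cccnc2)N2CCCCC2)ccc2cccnc12`: 8510 nM
- compound 3 `Oc1c(C(c2ccncc2)N2CCCCC2)ccc2cccnc12`: not yet measured

Of the two measured compounds, compound 2 has the lower number at 8510 nM, which means the stronger inhibition in this assay. The next change leads to compound 3 and keeps the piperidin-1-yl group and the shared core: pyridin-4-yl in place of pyridin-3-yl on a saturated chain carbon bound to an amine nitrogen in a ring and an aromatic carbon. In words, pyridin-4-yl stands in place of pyridin-3-yl on a saturated chain carbon bound to an amine nitrogen in a ring and an aromatic carbon.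

For the measured compounds named here, only one measured step exists, a 2.7-fold lower number from compound 1 to compound 2 (0.44 log units; beyond the scatter). It is modest, and it concerns pyrrolidin-1-yl and piperidin-1-yl, not the pyridinyl group that changes here. Going by the values given here, the data therefore hold no measured step for this kind of change, and no direction can be drawn from them. With nothing pointing either way, no shift beyond the scatter is expected. The expected change is a 1.0-fold lower number from compound 2 to compound 3 (0.00 log units; within the scatter). For compound 3 the estimated value is 8500 nM, with an expected range of 3500 nM to 20000 nM.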

Compound 3, half-maximal inhibitory concentration: 8320 nM
Compound 3: middle estimate off by 1.0-fold (0.01 log units), on the high side, and the stated range covers the measured number.
By their numbers in this assay, from the lowest: compounds 3 and 2 (each within the scatter of the next); then compound 1.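

In this assay, for the compounds shown here, the exchange of pyridin-3-yl for pyridin-4-yl on a saturated chain carbon bound to an amine nitrogen in a ring and an aromatic carbon gives a 1.0-fold lower number from compound 2 to compound 3 (0.01 log units; within the scatter) and is the first measured step at this position. Going by these compounds alone, it lies within the scatter, so with the piperidin-1-yl group and the shared core held fixed, this read-out does not separate the two pyridinyl groups, and the one step beyond the scatter remains a 2.7-fold lower number from compound 1 to compound 2 (0.44 log units; beyond the scatter) at the amine ring. No available evidence bears on why the two pyridinyl groups read alike.

Still open, going by these compounds, is whether the same holds for other groups on this carbon, such as pyridin-2-yl or phenyl, which would show whether the ring nitrogen of the pyridinyl group matters here at all. Also open, on these data alone, is whether pyridin-3-yl and pyridin-4-yl stay indistinguishable alongside pyrrolidin-1-yl, and whether a morpholin-4-yl group in place of piperidin-1-yl extends the step seen at the amine ring.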